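The source may report more compounds than this note shows. Statements on the series, on what has been measured and on what is new or still open speak of the compounds shown alone.

Compound 1 `COc1cc(OC)c(/C=C/S(=O)(=O)Cc2ccc(Cl)cc2)c(OC)c1` is the weakest of the three measured compounds in a functional assay on DLD-1 cells (Homo sapiens) for antiproliferative activity, read by trypan blue exclusion; a lower number here means a stronger inhibitor, a higher number a weaker inhibitor: compound 1 gives 15000 nM, while compound 2 `COc1ccc(CS(=O)(=O)/C=C/c2ccc(F)cc2)cc1` gives 2000 nM and compound 3 `COc1ccc(CS(=O)(=O)/C=C/c2ccc([N+](=O)[O-])cc2)cc1` gives 5000 nM. Among the compounds with values here, the only single-point step among them, a 2.5-fold higher number from compound 2 to compound 3 (0.40 log units; beyond the scatter), concerns the ring on the vinyl side and says nothing about the benzyl side. Compound 4 `COc1ccc(CS(=O)(=O)/C=C/c2c(OC)cc(OC)cc2OC)cc1` differs from compound 1 by methoxy in place of chloro on an aromatic carbon, that is, on the benzylic ring para to a large group. Within the data shown here, no measured step bears directly on this change; compounds 2 and 3 carry the methoxybenzyl sulfone, but they also carry a different ring on the vinyl side, so their lower numbers cannot be assigned to the benzyl substituent alone. Among the measured compounds shown here, with no direct precedent, compound 4 is expected to show only a modest change, leaning toward a lower number given what compounds 2 and 3 show for the methoxy-bearing benzyl side. The estimated step is a 1.9-fold lower number from compound 1 to compound 4 (0.27 log units; within the scatter), and compound 4 is expected to give about 8000 nM in this assay, within a range of 2500 nM to 25000 nM.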

Compound 4, half-maximal inhibitory concentration: 40 nM
The estimate for compound 4 lay 200-fold (2.30 log units) above the measured number, outside the stated range (below it).
By their numbers in this assay, from the lowest: compound 4; then compound 2; then compound 3; then compound 1.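

In this assay, the exchange of 4-chlorophenyl for 4-methoxyphenyl is a large step, a 380-fold lower number from compound 1 to compound 4 (2.57 log units; beyond the scatter), with the rest of the core of compound 1 unchanged. This shows that the aromatic carbon para to a large group is a highly sensitive position when the rest of the core is held as in compound 1. Within the data shown here, the only earlier step, a 2.5-fold higher number from compound 2 to compound 3 (0.40 log units; beyond the scatter), was far smaller and concerned a different part of the structure, so it could not reveal this sensitivity. Nothing available here accounts for the size of the step.

The compounds shown leave open whether an ethoxy group, a hydroxyl or an amine at this position would keep the low number of compound 4. They also leave open whether the exchange of chloro for methoxy would have a similar effect alongside the vinyl-side rings of compound 2 and compound 3.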